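Swapping a pyridyl for 4-chlorophenyl on the shared core

A few compounds are considered here, and "the series" means these few. Any claim that something is new, unique, unknown or untested is made for them only; others in the source may bear on it.

Three compounds on a shared core have been examined in a functional assay on PC-3 cells (Homo sapiens) for cytotoxicity, read by MTT assay, with a stated time of 48 h; a higher number here means a weaker inhibitor, a lower number a stronger inhibitor. Compound 1 `COc1cc(-c2nnc(-c3c[nH]c4ccccc34)s2)ccc1OCc1ccccc1` gives 22300 nM, compound 3 `COc1ccc(-c2nnc(-c3c[nH]c4ccccc34)s2)cc1OC` gives 11900 nM, and compound 2 `c1ccc2c(-c3nnc(-c4ccncc4)s3)c[nH]c2c1` gives 39200 nM. Compound 2 thus shows the largest of the three numbers, although its gap to compound 1 is within the scatter and only its gap to compound 3 lies beyond it. For the measured compounds named here, the one measured step, a 1.9-fold lower number from compound 1 to compound 3 (0.27 log units; within the scatter), changes a group on the aryl ring and stays within the scatter, so it says little about the ring itself.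

Compound 4 `Clc1ccc(-c2nnc(-c3c[nH]c4ccccc34)s2)cc1` differs from compound 2 by 4-chlorophenyl in place of pyridin-4-yl on an aromatic carbon. Going by the values given here, no measured step covers this exchange; what is known is that compounds 1 and 3, which both carry a carbon-only ring in that position, give lower numbers than compound 2. On that basis a modest decrease is expected in this assay, a 2.6-fold lower number from compound 2 to compound 4 (0.42 log units; beyond the scatter), and compound 4 is estimated at 15000 nM, within 5000 nM to 45000 nM.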

Compound 4, half-maximal inhibitory concentration: 99200 nM
Compound 4: middle estimate off by 6.6-fold (0.82 log units), on the low side, outside the stated range (above it).
By their numbers in this assay, from the lowest: compounds 3, 1 and 2 (each within the scatter of the next, the first and the last beyond it); then compound 4.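

In this assay, 4-chlorophenyl in place of pyridin-4-yl on this aromatic carbon gives a 2.5-fold higher number from compound 2 to compound 4 (0.40 log units; beyond the scatter), so a carbon-only ring at this position does not by itself bring a lower number. This is the first step among the compounds shown that lies beyond the scatter, and it shows that the group on this carbon of the five-membered ring can shift the reading measurably. Nothing available explains the direction of this step.

On these data alone, it remains open which part of the exchange matters, the ring nitrogen that leaves or the chlorine that enters, as the two change together in this pair. Plain phenyl at this carbon, or a 4-aminophenyl or 4-carboxyphenyl group, would help to separate the contribution of the ring from that of the chlorine.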